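This account rests on a few compounds, and the source may have more. Where it says the series, first, only, none or still open, it means among the compounds named here.

Measured compounds in a functional assay on HEK293 cells for agonist activity at melatonin receptor type 1B (Homo sapiens), read by calcium flux; on this read-out lower numbers stand for an effect already at smaller amounts and higher numbers for an effect only at larger amounts of compound:
- compound 1, `COc1cc2c(CN)coc2cc1C`: compound 1 gives 350000 nM
- compound 2, `COc1cc2c(CN(C)C)coc2cc1C`: compound 2 gives 130000 nM
- compound 3, `COc1cc2c(CN3CCN(C)CC3)coc2cc1C`: compound 3 gives 260000 nM

All three numbers sit at the weak end of the scale. Compound 3 stands second highest of the three; its gap to compound 1 and its gap to compound 2 both lie within the usual scatter, so no order among them can be read from these values. Going by the values given here, the one step that exceeds the scatter is a 2.7-fold lower number from compound 1 to compound 2 (0.43 log units; beyond the scatter), a modest move toward an effect at smaller amounts when methyl groups are added on an amine nitrogen.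

Compound 4, `COc1cc2c(CN3CCNCC3)coc2cc1C`, differs from compound 3 by hydrogen in place of methyl on an amine nitrogen in a ring. Among the compounds with values here, the only measured step that bears on it, the step from compound 1 to compound 2, concerns methyl groups on a chain amine rather than on a ring amine, and it runs the opposite way: methyl was added there, whereas here methyl is taken away. On that thin basis compound 4 is expected to show at most a small shift toward an effect only at larger amounts, an estimated step of a 1.3-fold higher number from compound 3 to compound 4 (0.13 log units; within the scatter), which may well fall inside the scatter. The estimate for compound 4 in this assay is 350000 nM, within a range from 130000 nM to 900000 nM.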

Compound 4, half-maximal effective concentration: 380000 nM
Beside the measured number, compound 4's estimate is 1.1-fold (0.04 log units) below it; the measured number falls inside the stated range.
By their numbers in this assay, from the lowest: compounds 2, 3, 1 and 4 (each within the scatter of the next, the first and the last beyond it).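

In this assay, taking the methyl off the amine nitrogen in the ring gives a 1.5-fold higher number from compound 3 to compound 4 (0.16 log units; within the scatter), so hydrogen and methyl cannot be told apart at this position, whereas adding methyl groups on the chain amine gave a 2.7-fold lower number from compound 1 to compound 2 (0.43 log units; beyond the scatter) on a step beyond the scatter. Going by these compounds alone, the piperazin-1-yl group of compound 4 likewise cannot be told apart from the amino group, with a 1.1-fold higher number from compound 1 to compound 4 (0.04 log units; within the scatter), while the comparison with dimethylamino gives a 2.9-fold higher number from compound 2 to compound 4 (0.47 log units; beyond the scatter), the only new step beyond the scatter and still a modest one. No evidence at hand speaks to what lies behind these steps.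

From the compounds shown here alone, whether a larger group on this ring nitrogen, such as benzyl or acetyl, would shift the number remains open. So does the effect of a piperidine ring or a longer chain in place of the present link to the core.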